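Mirror Image of Compound 2 in the Modulator Series

The source may report more compounds than this note shows. Statements on the series, on what has been measured and on what is new or still open speak of the compounds shown alone.

Two compounds carry measurements in an assay for positive allosteric modulation of metabotropic glutamate receptor 2 (Rattus norvegicus); on this read-out lower numbers stand for an effect already at smaller amounts and higher numbers for an effect only at larger amounts of compound. Compound 1 `Cc1c(OCCCCOc2ccc(C(=O)O)cc2F)ccc(C(=O)CC(C)(C)C)c1O` gives 75 nM, and compound 2 `Cc1c(OC[C@H](C)Oc2ccc(F)c(C(=O)O)c2)ccc(C(=O)CC(C)(C)C)c1O` gives 142 nM; these two values lie within the usual scatter of each other. Compound 3 `Cc1c(OC[C@@H](C)Oc2ccc(F)c(C(=O)O)c2)ccc(C(=O)CC(C)(C)C)c1O` is the mirror image of compound 2: the two compounds have the same atoms and bonds and differ only in configuration as drawn: 1 of 1 stereo elements differ; a stereocentre at a saturated chain carbon is drawn S in compound 2 and R in compound 3. For the measured compounds named here, no measured pair in this set shows how such a change in configuration alone plays out, so the direction of the step is open; a move either way beyond the scatter is possible, as is none at all. Compound 3 is expected to give roughly 220 nM, within 50 nM to 1500 nM, meaning a step of a 1.5-fold higher number from compound 2 to compound 3 (0.19 log units; within the scatter) of uncertain direction.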

Compound 3, half-maximal effective concentration: 112 nM
Compound 3: the middle estimate sits 2.0-fold (0.29 log units) above what was measured; low and high end bracket the measured number.
By their numbers in this assay, from the lowest: compounds 1, 3 and 2 (each within the scatter of the next).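

In this assay, turning the stereocentre at the saturated chain carbon from S to R gives a 1.3-fold lower number from compound 2 to compound 3 (0.10 log units; within the scatter). For the compounds shown here, this is the first pair here that isolates configuration, so the comparison is a clean one: the fact that compounds 2 and 3 differ only in the configuration as drawn. For this pair, the drawn configuration at this carbon makes no difference that can be told apart from the scatter of repeated measurements.

On these data alone, whether that holds when an ethyl group sits on this stereocentre remains open. So does whether it holds when an amide takes the place of the carboxylic acid.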